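Removing the acetyl from a second core

The source may report more compounds than this note shows. Statements on the series, on what has been measured and on what is new or still open speak of the compounds shown alone.

Of the compounds shown here, three of closely related build have been measured in a functional assay (aorta) with Oryctolagus cuniculus as the target; on this read-out lower numbers stand for stronger inhibition and higher numbers for weaker inhibition. Compound 1 `COc1ccc([C@@H]2Cc3c(Cl)cccc3N(C[C@@H]3CCCN3)C(=O)[C@@H]2OC(C)=O)cc1` gives 120 nM. Compound 3 `COc1ccc([C@@H]2Cc3c(Cl)cccc3N(C[C@@H]3CCCN3)C(=O)[C@@H]2O)cc1`, which carries the change (hydrogen in place of acetyl on an oxygen on a saturated carbon), gives 130 nM. The step of a 1.1-fold higher number from compound 1 to compound 3 (0.03 log units; within the scatter) therefore shows that taking off the acetyl leaves the read-out where it was. Compound 2 `COc1ccc([C@@H]2Cc3cc(OC)ccc3N(C[C@@H]3CCCN3)C(=O)[C@@H]2OC(C)=O)cc1` rests on a different core; how that core differs from the core of compound 1 is not broken down here. In this assay compound 2 gives 230 nM, a number that sits within the usual scatter of both compound 1 and compound 3, so nothing can be said about an order among the three.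

Compound 4 `COc1ccc([C@@H]2Cc3cc(OC)ccc3N(C[C@@H]3CCCN3)C(=O)[C@@H]2O)cc1` has not yet been measured. It stands to compound 2 as compound 3 stands to compound 1: the change hydrogen in place of acetyl on an oxygen on a saturated carbon is made at a place described in exactly the same words as for the earlier pair, so it is the same change, carried out on the second core. Among the measured compounds shown here, the only guide to its effect is the step from compound 1 to compound 3, which stayed within the scatter. On that basis the step from compound 2 to compound 4 is expected to be a 1.1-fold higher number from compound 2 to compound 4 (0.04 log units; within the scatter), matching a 1.1-fold higher number from compound 1 to compound 3 (0.03 log units; within the scatter) in size. For compound 4 in this assay a value of about 250 nM is therefore estimated, most likely between 120 nM and 500 nM.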

Compound 4, half-maximal inhibitory concentration: 1120 nM
Beside the measured number, compound 4's estimate is 4.5-fold (0.65 log units) below it; the whole stated range lies below it.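

On the second core, taking off the acetyl is no silent change: it gives a 4.9-fold higher number from compound 2 to compound 4 (0.69 log units; beyond the scatter). Set beside the earlier pair, the same change from acetoxy to hydroxy did not carry over from the core of compound 1 to the core of compound 2 with the same size, so in this series a step read on one core cannot simply be transferred to the other: the same change on two cores in this assay, a 1.1-fold higher number (0.03 log units; within the scatter) from compound 1 to compound 3 and a 4.9-fold higher number (0.69 log units; beyond the scatter) from compound 2 to compound 4, 4.5-fold (0.65 log units) apart, beyond the scatter of two such steps This does not show which feature of the two cores sets the size of the step, and two pairs say nothing about how the change would behave on any further core.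

The compounds shown carry only acetoxy or hydroxy on this saturated ring carbon, so it stays open how the two cores would respond to a different group there, such as an amine or an ester with a longer chain than acetyl. On these data alone, it also stays open whether the gap between the two steps seen in this assay would appear on any other read-out, as all the numbers here come from that single assay.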